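Shortening the ester alkyl chain of an adenine hydroxypropanoate

The source may hold more compounds than are shown below. What is called first, only, known or untested is meant among the compounds shown, and "the series" means these compounds.

Compound 1 `CCCCCOC(=O)C(O)Cn1cnc2c(N)ncnc21` gives 200 ug/mL in a functional assay on Vero cells (Chlorocebus sabaeus) for cytotoxicity; a higher number here means that more compound is tolerated, a lower number that less compound is tolerated.
Compound 2 `CCCOC(=O)C(O)Cn1cnc2c(N)ncnc21` gives > 400 ug/mL in this assay, which is a limit of the assay and not a number.
Compound 3 `CCC(C)OC(=O)C(O)Cn1cnc2c(N)ncnc21` gives > 400 ug/mL in this assay, also a limit of the assay.

The change hydrogen in place of ethyl on a saturated chain carbon, three bonds along the chain from an oxygen next to a carbonyl group made a step of an at least 2.0-fold higher number from compound 1 to compound 2 (0.30 log units; that floor lies within the scatter). The cores of compound 1 and compound 3 differ by sec-butyl in place of pentyl on an oxygen next to a carbonyl group, a step of an at least 2.0-fold higher number from compound 1 to compound 3 (0.30 log units; that floor lies within the scatter), while a step that the two limits leave unreadable from compound 2 to compound 3. Compound 4 `CCOC(=O)C(O)Cn1cnc2c(N)ncnc21` carries the same kind of change as compound 2, (hydrogen in place of ethyl on a saturated chain carbon bound to an oxygen next to a carbonyl group and a saturated chain carbon), but at a different place: here the carbon is bound to an oxygen next to a carbonyl group and a saturated chain carbon, not three bonds along the chain from that oxygen. Two of the three values already sit at the limit of > 400 ug/mL in this assay, at which 2 of the 3 values shown sit, and a step of a number no higher from compound 3 to compound 4 (the limit leaves the size open) is expected because of the limit of > 400 ug/mL in this assay, at which 2 of the 3 values shown sit. Compound 4 is estimated at 400 ug/mL, between 200 ug/mL and 800 ug/mL.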

Compound 4, minimum cytotoxic concentration: > 400 ug/mL
Compound 4 ended at the assay's limit; the forecaster's own chance of this, stated with the estimate: 75%; the middle value lies on the limit itself.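

Compound 4 gives > 400 ug/mL in this assay, which is a limit of the assay and not a number. The steps among compound 2, compound 3 and compound 4 cannot be read, because these compounds share one limit: the limit of > 400 ug/mL in this assay, at which 3 of the 4 values shown sit. The only readable new step is an at least 2.0-fold higher number from compound 1 to compound 4 (0.30 log units; that floor lies within the scatter), so whether hydrogen in place of ethyl has the same effect when carried from one core to another is not shown, although no core shown here falls short of the limit once the pentyl chain is gone.

Going by these compounds, whether a longer chain than pentyl would lower the tolerated amount remains open. So does the result of a carboxylic acid in place of the ester.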